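The source may report more compounds than this note shows. Statements on the series, on what has been measured and on what is new or still open speak of the compounds shown alone.

Working notes on the series. The shared core carries an enone linked to an aryl ketone. Compound 1 `COc1ccc(-c2cc(/C=C/C(=O)c3ccc(N)cc3)[nH]n2)cc1` gives 20900 nM in a functional assay on NCI-H460 cells (Homo sapiens) for inhibition, read by sulforhodamine B assay, with a stated time of 48 h; on this read-out lower numbers stand for higher toxicity in this test and higher numbers for lower toxicity in this test. Compound 2 `COc1cc(-c2cc(/C=C/C(=O)c3ccc(N)cc3)[nH]n2)cc(OC)c1OC` gives 44800 nM in this assay. Within the data shown here, on the numbers so far compound 2 stands highest; the only other compound, compound 1, sits a step beyond the scatter below it.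

The next compound, compound 3 `COc1cc(-c2cc(/C=C/C(=O)c3ccc(Cl)c(Cl)c3)[nH]n2)cc(OC)c1OC`, differs from compound 2 in one place: 3,4-dichlorophenyl in place of 4-aminophenyl on a carbonyl carbon, so the ketone now carries a chlorinated ring instead of the aminophenyl ring. Among the measured compounds shown here, no measured pair shows this change, so the direction and size of the step rest on judgement alone. A modest step towards a lower number, of a size that may or may not clear the scatter, is expected, given that compound 2 at 44800 nM stands at the top of the current range. The estimated step from compound 2 to compound 3 in this assay is a 1.8-fold lower number from compound 2 to compound 3 (0.25 log units; within the scatter). Compound 3 is expected to give about 25000 nM in this assay, with a range from 8000 nM to 70000 nM.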

Compound 3, concentration lethal to 50% of the cells: > 100000 nM
Compound 3: only a limit was reported (the forecaster's own chance of this, stated with the estimate: 10%); middle value at least 4.0-fold (0.60 log units) from the limit.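

The ketone position is not indifferent to its aryl group: 3,4-dichlorophenyl in place of 4-aminophenyl on a carbonyl carbon gives an at least 2.2-fold higher number from compound 2 to compound 3 (0.34 log units; beyond the scatter), towards lower toxicity in this test. In this assay compound 3 gives > 100000 nM, and this is a limit of the assay, not a number. The step is therefore only a lower bound, and its full size cannot be read from the one value that rests on a limit: the limit of > 100000 nM in this assay, at which 1 of the 3 values shown sits.

The swap removes the amine and adds both chlorines at once, so the compounds shown leave open which of these goes with the shift. Also open, from the compounds shown here alone, is how a plain phenyl or a hydroxyphenyl would read on this carbonyl carbon, and whether 3,4-dichlorophenyl on the core of compound 1 moves the same way.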